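The compounds below may be only part of what the source reports. "The series", "measured", "known", "first", "only" and "open" are said of these compounds alone.

Going by the values given here, compound 2 `CN1CCC(c2cn(-c3ccncc3)c3ccc(-c4ccnn4C)cc23)CC1` gives 19 nM in an in vitro assay on BHK cells for displacement of a labelled ligand from Alpha-1A adrenergic receptor (Bos taurus), read by scintillation counting, with a stated time of 20 min (a lower number here means a stronger inhibitor, a higher number a weaker inhibitor), the higher of the two numbers measured so far; compound 1 `CN1CCC(c2cn(-c3ccc(F)cc3)c3ccc(-c4ccnn4C)cc23)CC1` gives 0.32 nM in this assay, and the only measured step, a 59-fold higher number from compound 1 to compound 2 (1.77 log units; beyond the scatter), separates them. Compound 3 `CN1CCC(c2cn(-c3ccncc3)c3ccc(-c4cccnc4)cc23)CC1` differs from compound 2 by pyridin-3-yl in place of 1-methyl-1H-pyrazol-5-yl on an aromatic carbon. Among the compounds with values here, that single measured step concerns the group on the aromatic nitrogen, not this carbon, so no measured step bears directly on the change. The step of no change at the digits printed from compound 2 to compound 3 (within the scatter) is therefore expected to stay within the scatter. The estimate for compound 3 is 19 nM, ranging from 6 nM to 60 nM.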

Compound 3, inhibition constant: 22 nM
Estimate against measurement, compound 3: 1.2-fold (0.06 log units) below, and the stated range covers the measured number.
By their numbers in this assay, from the lowest: compound 1; then compounds 2 and 3 (each within the scatter of the next).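

On the aromatic carbon of the six-membered ring of carbon only, pyridin-3-yl in place of 1-methyl-1H-pyrazol-5-yl gives a 1.2-fold higher number from compound 2 to compound 3 (0.06 log units; within the scatter) in this assay. With pyridin-4-yl on the aromatic nitrogen, a five-membered aromatic ring and a six-membered one therefore read alike at this position, unlike the large step seen at the nitrogen. No measurement at hand offers a reason for this match. On these data alone, whether the exchange holds with 4-fluorophenyl on the nitrogen, as in compound 1, remains open. So does the outcome at this carbon for an amine, a carboxylic acid or a longer chain.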